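Branching of the ether side chain on the shared core

This account rests on a few compounds, and the source may have more. Where it says the series, first, only, none or still open, it means among the compounds named here.

Compound 1 `CCC(C)COc1cccc2ccc(N)nc12` is the reference point of this set. In an assay on cells with melanin-concentrating hormone receptor 1 (Homo sapiens) as the target, read by radioligand binding (a lower number here means a stronger inhibitor, a higher number a weaker inhibitor), compound 1 gives 36 nM, the lowest of the two numbers recorded, and its nearest neighbour is compound 3 `CC(C)(C)CCOc1cccc2ccc(N)nc12`, which in this assay gives 201 nM; the step of a 5.6-fold higher number from compound 1 to compound 3 (0.75 log units; beyond the scatter) is modest but beyond the scatter. Compound 2 `Nc1ccc2cccc(OCC3CC3)c2n1` returns only a limit in this assay, > 2000 nM, and is not a number. That limit is the one described at the limit of > 2000 nM in this assay, at which 1 of the 3 values shown sits. The step of an at least 55-fold higher number from compound 1 to compound 2 (1.74 log units; beyond the scatter) is large, and the step of an at least 9.9-fold lower number from compound 2 to compound 3 (0.99 log units; beyond the scatter) is at least modest.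

Compound 4 `CCCC(C)Oc1cccc2ccc(N)nc12` differs from compound 1 in a single place: 1-methylbutyl in place of 2-methylbutyl on an oxygen on an aromatic ring. The change keeps the chain length and only moves the branch, so neither the large loss seen on shortening to cyclopropyl nor the modest loss on growing to neopentyl applies directly. Both measured steps weaken on leaving sec-butyl, so a small loss is the more probable direction. Compound 4 is expected to give about 60 nM in this assay, within 20 nM to 200 nM. The implied step a 1.7-fold higher number from compound 1 to compound 4 (0.22 log units; within the scatter) is estimated to sit near the edge of the scatter.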

Compound 4, half-maximal inhibitory concentration: 105 nM
For compound 4 the middle estimate is 1.8-fold (0.24 log units) below the measured one, and the stated range covers the measured number.
By their numbers in this assay, from the lowest: compound 1; then compounds 4 and 3 (each within the scatter of the next). At a limit, above all of these: compound 2.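

Moving the branch alone, with 5 carbons in both chains and the same atoms overall, already shifts the number in this assay: the step of a 2.9-fold higher number from compound 1 to compound 4 (0.46 log units; beyond the scatter) shows that the place of the branch counts on this oxygen-bound chain, not only its size. The step of a 1.9-fold lower number from compound 3 to compound 4 (0.28 log units; within the scatter) lies within the scatter, so 1-methylbutyl and 3,3-dimethylbutyl are not told apart here, and among the measured chains only the 2-methylbutyl of compound 1 stands clear of the others. The step of an at least 19-fold lower number from compound 2 to compound 4 (1.27 log units; beyond the scatter) is large, but its starting point is a limit and not a number: the limit of > 2000 nM in this assay, at which 1 of the 4 values shown sits.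

Still open, as far as these compounds go, is how a straight n-pentyl chain compares with these branched chains, and whether a longer chain, or one ending in an amine or a carboxylic acid, keeps a number in the range of compound 1 in this assay. From the compounds shown here alone, the structures of compound 1 and compound 4 also state no handedness at the branch carbon, so what each separate mirror-image form gives remains unknown.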